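The compounds below may be only part of what the source reports. "The series", "measured", "known", "first", "only" and "open" are said of these compounds alone.

Of the compounds shown here, two have been measured so far in a functional assay on the whole organism (Ear, strain Kunming) for inhibition, with Mus musculus as the target, with a stated time of 2 h, at a dose of 200 mg/kg by the oral route; on this read-out higher numbers stand for more inhibition at the one dose given (going by the name of the read-out) and lower numbers for less inhibition: compound 1, `CN(C)c1ccc(/C=C/C(=O)c2ccc(O)cc2O)cc1`, and compound 2, `COc1cc(/C=C/C(=O)c2ccc(O)cc2)ccc1O`. In this assay compound 1 gives 62.6%, while compound 2 gives 7.83%. Compound 2 thus stands lowest of the two numbers; its nearest neighbour is compound 1, whose number is higher by an amount well beyond the usual scatter. For the measured compounds named here, the two compounds differ in more than one place, so no single step between them is counted.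

Compound 3, `COc1cc(/C=C/C(=O)c2ccc(O)cc2O)ccc1O`, has not yet been measured in this assay. It differs from compound 2 by hydroxy in place of hydrogen on an aromatic carbon. Compound 1, which also carries the entering hydroxy group, gives 62.6% in this assay. Going by the values given here, compound 1 differs from compound 2 in more than one place, and no step between the two is counted. The step from compound 2 to compound 3 in this assay is expected to be a rise, a number 22.2 percentage points higher from compound 2 to compound 3 (beyond the scatter), probably beyond the scatter yet uncertain in size. Compound 3 is estimated at 30% in this assay, with a range from 10% to 55%.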

Compound 3, a percentage reported as inhibition, in the whole organism at one dose (the size of the read-out at that dose, not a potency): 25.2%
Compound 3: the middle estimate sits 4.8 percentage points above what was measured; low and high end bracket the measured number.
By their numbers in this assay, from the lowest: compound 2; then compound 3; then compound 1.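

In this assay, for the compounds shown here, hydroxy in place of hydrogen on an aromatic carbon, ortho to a large group and meta to a hydroxy group, gives a number 17.4 percentage points higher from compound 2 to compound 3 (beyond the scatter), the first single-place step that can be read. This position therefore accepts the added hydroxy group without loss of inhibition at the one dose given, and the change raises the read-out by a modest amount, though this rests on a single pair. No measurement at hand accounts for the rise.

The compounds shown leave open whether the rise belongs to hydroxy itself or would also appear with another group on that aromatic carbon, such as a fluorine atom, an amine or a carboxylic acid. Also open, going by these compounds, is whether the same step would appear with other groups elsewhere on the shared core, and whether it would hold at other doses, since a single-dose percentage is not a potency.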